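The source may report more compounds than this note shows. Statements on the series, on what has been measured and on what is new or still open speak of the compounds shown alone.

Series notes. In a functional assay on PC-3 cells (Homo sapiens) for cytotoxicity, read by MTT assay, with a stated time of 72 h (on this read-out higher numbers stand for weaker inhibition and lower numbers for stronger inhibition), compound 2 `O=S(=O)(c1ccccc1)c1nc2ccccc2nc1N1CCc2ccccc2C1` gives 5010 nM, and compound 3 `Cc1ccc(S(=O)(=O)c2nc3ccccc3nc2N2CCc3ccccc3C2)cc1` gives 22400 nM. Compound 3 stands highest of the two numbers, set apart from its nearest neighbour by the step of a 4.5-fold higher number from compound 2 to compound 3 (0.65 log units; beyond the scatter). Compound 1 `COc1ccc(S(=O)(=O)c2nc3ccccc3nc2N2CCCC2)cc1` gives only a limit in this assay, > 50000 nM, noted as the limit of > 50000 nM in this assay, at which 1 of the 3 values shown sits. Compound 4 `COc1ccc(S(=O)(=O)c2nc3ccccc3nc2N2CCc3ccccc3C2)cc1` differs from compound 3 by methoxy in place of methyl on an aromatic carbon. Among the compounds with values here, no measured step covers this exchange; the single step in the set, a 4.5-fold higher number from compound 2 to compound 3 (0.65 log units; beyond the scatter), concerns methyl in place of hydrogen and raised the number, while compound 1 shows that a methoxy-bearing member on a different core reached the limit. For compound 4 in this assay a step of a 1.6-fold higher number from compound 3 to compound 4 (0.19 log units; within the scatter) is expected, a further rise in the number with a fair chance of a limit. The estimate for compound 4 is 35000 nM, in the range 12000 nM to 100000 nM.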

Compound 4, half-maximal inhibitory concentration: > 50000 nM
Compound 4: no number, only a limit; the forecaster's own chance of this, stated with the estimate: 35%; middle value at least 1.4-fold (0.15 log units) away from the limit.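

In this assay compound 4 gives a limit, not a number: the limit of > 50000 nM in this assay, at which 2 of the 4 values shown sit.

On the ring position para to a large group, the change to methoxy gives an at least 2.2-fold higher number from compound 3 to compound 4 (0.34 log units; beyond the scatter), and against the unsubstituted member it gives an at least 9.9-fold higher number from compound 2 to compound 4 (0.99 log units; beyond the scatter), so among compounds 2, 3 and 4 both substituents raise the number over hydrogen. Compound 1 and compound 4 both sit at a limit, and the step between them cannot be read.

From the compounds shown here alone, the true size of the methoxy step remains open. So does whether an amine or a carboxylic acid at this position would give a number under that of compound 2.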